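The source may hold more compounds than are shown below. What is called first, only, known or untested is meant among the compounds shown, and "the series" means these compounds.

Measured compounds:
- compound 1 `Cc1cccc(N2CCC(C(=O)Nc3ccc4c(c3)NC(=O)CO4)CC2)c1` — 490 nM
- compound 2 `O=C(Nc1cccc2[nH]ccc12)C1CCN(c2cccc(C(F)(F)F)c2)CC1` — 230 nM
- compound 3 `CC(=O)N1CCc2cccc(NC(=O)C3CCN(c4cccc(C(F)(F)F)c4)CC3)c21` — 5610 nM

In a functional assay for antagonist activity at transient receptor potential cation channel subfamily V member 1 (Homo sapiens), read by FLIPR and calcium flux (on this read-out lower numbers stand for stronger inhibition and higher numbers for weaker inhibition), compound 1 gives 490 nM, the second highest of the three numbers. Its nearest neighbour is compound 2, which gives 230 nM, a gap that lies beyond the scatter. Compound 3 gives 5610 nM, the highest number of the three and far from compound 1, also beyond the scatter. Among the compounds with values here, no two of the measured compounds differ in one place only, so no single step has been measured in this set.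

Compound 4 `Cc1ccccc1N1CCC(C(=O)Nc2ccc3c(c2)NC(=O)CO3)CC1` is not yet measured. It differs from compound 1 by 2-methylphenyl in place of 3-methylphenyl on an amine nitrogen in a ring. Within the data shown here, the measured compounds contain no pair that isolates such a change, so the size of the step cannot be read from them. The expectation for this assay is a rise in the number beyond the scatter. For compound 4 a value of about 1500 nM is estimated, within a range from 500 nM to 5000 nM. The step expected is a 3.1-fold higher number from compound 1 to compound 4 (0.49 log units; beyond the scatter).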

Compound 4, half-maximal inhibitory concentration: 150 nM
Beside the measured number, compound 4's estimate is 10-fold (1.00 log units) above it; measured number outside the range, below it.
By their numbers in this assay, from the lowest: compounds 4 and 2 (each within the scatter of the next); then compound 1; then compound 3.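

Notes on the group on the amine nitrogen in a ring: in this assay, 2-methylphenyl in place of 3-methylphenyl gives a 3.3-fold lower number from compound 1 to compound 4 (0.51 log units; beyond the scatter) and is the first single change that can be read in this series. The two groups match in heavy atoms, ring type and hydrogen-bond counts, so the read-out at this position responds to a difference in how the same atoms are joined, not only to which atoms are present. No measurement at hand accounts for the direction or size of this step.

From the compounds shown here alone, whether a plain phenyl, a chlorophenyl or a methoxyphenyl at this position would match 2-methylphenyl remains open. Also open, going by these compounds, is whether the same change would give a similar step on the cores of compound 2 and compound 3, which carry trifluoromethyl on their aromatic ring.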